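This account rests on a few compounds, and the source may have more. Where it says the series, first, only, none or still open, it means among the compounds named here.

Among the measured compounds shown here, in a functional assay on the whole organism (Peritoneal cavity) with Rattus norvegicus as the target (a lower number here means that less compound is needed, a higher number that more compound is needed for the effect), compound 1 (`CC(C)(/C=N/OCC(=O)O)Cc1c(SC(C)(C)C)c2cc(OCc3ccc4ccccc4n3)ccc2n1Cc1ccc(Cl)cc1`) gives 0.24 umol/kg and holds the lower of the two numbers measured so far, while compound 2 (`CC(C)c1ccc2c(c1)c(SC(C)(C)C)c(CC(C)(C)CNC(N)=O)n2Cc1ccc(Cl)cc1`) gives 11 umol/kg and lies beyond the scatter from it. Compound 3 (`CC(C)(/C=N/OCC(=O)O)Cc1c(SC(C)(C)C)c2cc(OCc3ccccn3)ccc2n1Cc1ccc(Cl)cc1`), still unmeasured, carries pyridin-2-yl in place of quinolin-2-yl on a saturated chain carbon bound to an oxygen on an aromatic ring. For the measured compounds named here, no measured pair shows this change, so only a modest rise in the number, meaning more compound needed, is expected (a 2.5-fold higher number from compound 1 to compound 3 (0.40 log units; beyond the scatter)). Compound 3 is expected at 0.6 umol/kg (estimated range 0.15 umol/kg to 2.5 umol/kg).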

Compound 3, dose for half-maximal effect: 0.12 umol/kg
Compound 3: the middle estimate sits 5.0-fold (0.70 log units) above what was measured; measured number outside the range, below it.
By their numbers in this assay, from the lowest: compounds 3 and 1 (each within the scatter of the next); then compound 2.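

With pyridin-2-yl in place of quinolin-2-yl on a saturated chain carbon bound to an oxygen on an aromatic ring, this assay gives a 2.0-fold lower number from compound 1 to compound 3 (0.30 log units; within the scatter). The six-membered aromatic ring of carbon only in quinolin-2-yl can therefore leave this position without the number moving beyond the scatter, so compound 1 and compound 3 cannot be told apart here. Nothing available explains this result. The compounds shown leave open whether phenyl or a simple methyl group in place of pyridin-2-yl would keep the number in this range.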